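Replacing the Anilino Aryl Group in a Nitrile Series

A few compounds are considered here, and "the series" means these few. Any claim that something is new, unique, unknown or untested is made for them only; others in the source may bear on it.

Of the compounds shown here, three sharing one core have been measured in a functional assay on ECa-109 cells (Homo sapiens) for inhibition, read by MTT assay, with a stated time of 72 h; a higher number here means a weaker inhibitor, a lower number a stronger inhibitor. Compound 1 `CC(C)c1ccc(-c2nc(SCc3cn(CC(=O)NC(=O)Nc4ccccn4)nn3)nc(Nc3cccc(C(F)(F)F)c3)c2C#N)cc1` gives 24200 nM, compound 2 `CC(C)c1ccc(-c2nc(SCc3cn(CC(=O)NC(=O)Nc4ccccn4)nn3)nc(Nc3ccccc3F)c2C#N)cc1` gives 15500 nM, and compound 3 `COc1ccccc1Nc1nc(SCc2cn(CC(=O)NC(=O)Nc3ccccn3)nn2)nc(-c2ccc(C(C)C)cc2)c1C#N` gives 8960 nM. Compound 2 stands second highest of the three: the step of a 1.6-fold lower number from compound 1 to compound 2 (0.19 log units; within the scatter) and the step of a 1.7-fold lower number from compound 2 to compound 3 (0.24 log units; within the scatter) both lie within the scatter, while only a 2.7-fold lower number from compound 1 to compound 3 (0.43 log units; beyond the scatter) reaches beyond it. Compound 4 `CC(C)c1ccc(Nc2nc(SCc3cn(CC(=O)NC(=O)Nc4ccccn4)nn3)nc(-c3ccc(C(C)C)cc3)c2C#N)cc1` carries the change (4-isopropylphenyl in place of 2-fluorophenyl on a nitrogen on an aromatic ring). Going by the values given here, no measured step exchanges a halogen-bearing ring for an alkyl-bearing one, so the two nearest steps offer only their small size as a guide. Compound 4 is therefore expected to sit near compound 2, with an estimated step of a 1.3-fold lower number from compound 2 to compound 4 (0.11 log units; within the scatter). Compound 4 is estimated at 12000 nM, in the range 4000 nM to 40000 nM.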

Compound 4, half-maximal inhibitory concentration: 2490 nM
Compound 4: the middle estimate sits 4.8-fold (0.68 log units) above what was measured; measured number outside the range, below it.
By their numbers in this assay, from the lowest: compound 4; then compounds 3, 2 and 1 (each within the scatter of the next, the first and the last beyond it).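

Going by these compounds alone, at this position the earlier aryl groups gave only one step beyond the scatter, whereas in this assay 4-isopropylphenyl brings a 6.2-fold lower number from compound 2 to compound 4 (0.79 log units; beyond the scatter) and a 3.6-fold lower number from compound 3 to compound 4 (0.56 log units; beyond the scatter) and a 9.7-fold lower number from compound 1 to compound 4 (0.99 log units; beyond the scatter) as well. Within the data shown here, compound 4 is therefore the strongest of the four, the only one with steps to all the others beyond the scatter. Nothing measured here accounts for this gain. Going by these compounds, it remains open whether the isopropyl group itself carries the change, or whether a tert-butyl group in its place or a plain phenyl ring would do the same.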